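Replacing the oxadiazole of compound 2 with an acyclic oxime ether

The compounds below may be only part of what the source reports. "The series", "measured", "known", "first", "only" and "open" are said of these compounds alone.

Measured compounds:
compound 1, `c1ccc(-c2cnco2)c(NCC2=NCCN2)c1`, 17.4 nM
compound 2, `Cc1noc(-c2ccccc2NCC2=NCCN2)n1`, 661 nM

In a functional assay for activation of Alpha-1A adrenergic receptor (Homo sapiens), read by calcium flux (on this read-out lower numbers stand for an effect already at smaller amounts and higher numbers for an effect only at larger amounts of compound), compound 1 gives 17.4 nM, and compound 2 gives 661 nM. For the measured compounds named here, compound 2 therefore stands at the highest of the two numbers, with compound 1 as its only neighbour; the step of a 38-fold higher number from compound 1 to compound 2 (1.58 log units; beyond the scatter) came with the oxadiazole taking the place of the oxazole on the shared core. Compound 3, `CC/C(=N\OC)c1ccccc1NCC1=NCCN1`, is the next variation at that same position: a group of 6 heavy atoms (4 carbon, 1 nitrogen, 1 oxygen; no ring) in place of a group of 6 heavy atoms (3 carbon, 2 nitrogen, 1 oxygen; one five-membered aromatic ring with 3 hetero atoms), on an aromatic carbon. Going by the values given here, no measured step covers the loss of a five-membered aromatic ring in favour of an open chain, so the one known step serves only as a sign that changes at this position can move the number strongly in this assay. With that uncertainty, compound 3 is expected to stay near compound 2, estimated at 600 nM (range 100 nM to 4000 nM), and the step of a 1.1-fold lower number from compound 2 to compound 3 (0.04 log units; within the scatter) is expected to remain within the scatter.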

Compound 3, half-maximal effective concentration: 3.31 nM
Beside the measured number, compound 3's estimate is 180-fold (2.26 log units) above it; the measured number lies below the stated range.
By their numbers in this assay, from the lowest: compound 3; then compound 1; then compound 2.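

In this assay, the open chain of compound 3, with its double bond outside any ring, gives a 200-fold lower number from compound 2 to compound 3 (2.30 log units; beyond the scatter), so a five-membered aromatic ring is not needed at this position for a low number. The same change also goes past the oxazole, with a 5.3-fold lower number from compound 1 to compound 3 (0.72 log units; beyond the scatter), which leaves compound 3 with the lowest number of the three; since compound 2 and compound 3 carry groups with the same count of heavy atoms, that count alone does not set the number here. Nothing available bears on what lies behind these steps.

As far as these compounds go, it remains open how far the chain tolerates change, for instance a longer chain on the oxygen or an amine in place of the oxime ether. The compounds shown also leave open whether the opposite geometry at the double bond would keep the number this low.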